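Swapping Two Halogens on a Weak Growth Inhibitor

A few compounds are considered here, and "the series" means these few. Any claim that something is new, unique, unknown or untested is made for them only; others in the source may bear on it.

Of the compounds shown here, three have been measured in a functional assay on DU-145 cells (Homo sapiens) for inhibition, read by trypan blue exclusion, with a stated time of 96 h; on this read-out lower numbers stand for stronger inhibition of growth and higher numbers for weaker inhibition of growth. Compound 1 `COc1ccccc1/C=C(/SCc1ccc(Cl)c(Cl)c1)C(=O)c1ccc(Cl)cc1` gives 10000 nM, compound 2 `Cc1ccc(S(=O)(=O)/C(=C/c2ccc(C)s2)C(=O)c2ccc(Cl)cc2)cc1` gives 50000 nM, and compound 3 `O=C(/C(=C\c1cc(Br)c(O)c(Br)c1)S(=O)(=O)Cc1ccc(Br)cc1)c1ccc(Br)cc1` gives 25000 nM. Compound 3 lies within the scatter of compound 2, so those two cannot be told apart. Its number is higher than that of compound 1 by more than the scatter, which means weaker inhibition of growth.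

Compound 4 `O=C(/C(=C\c1cc(Cl)c(O)c(Cl)c1)S(=O)(=O)Cc1ccc(Br)cc1)c1ccc(Br)cc1` has not yet been measured. It carries 3,5-dichloro-4-hydroxyphenyl in place of 3,5-dibromo-4-hydroxyphenyl on a double-bonded chain carbon bound to a double-bonded chain carbon. The rest of the structure stays the same.

For the measured compounds named here, no two measured compounds differ in only one place, so the data offer no direct guide to the size of this swap. With so little to go on, the expectation stays anchored on compound 3 at 25000 nM, and no change beyond the scatter is expected in this assay. The estimated step is no change at the digits printed from compound 3 to compound 4 (within the scatter). Compound 4 is expected at 25000 nM, within an estimated range of 10000 nM to 60000 nM.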

Compound 4, concentration for 50% growth inhibition: 25000 nM
The estimate for compound 4 equals the measured number at the digits printed, within the range that was stated.
By their numbers in this assay, from the lowest: compound 1; then compounds 3, 4 and 2 (each within the scatter of the next).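

In this assay, for the compounds shown here, the change to 3,5-dichloro-4-hydroxyphenyl in place of 3,5-dibromo-4-hydroxyphenyl provides the first readable comparison of two compounds that differ in only one place, and the step is no change at the digits printed from compound 3 to compound 4 (within the scatter) for this pair. On a double-bonded chain carbon bound to a double-bonded chain carbon, these two halogen patterns therefore cannot be told apart on this shared core. No separate measurement bears on the reason for this result.

A single step between two halogens leaves open how this position responds to a different kind of change, such as an amine or a carboxylic acid on the ring. It also leaves open whether the same halogen swap would read alike on the core of compound 1 or of compound 2.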